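A few compounds are considered here, and "the series" means these few. Any claim that something is new, unique, unknown or untested is made for them only; others in the source may bear on it.

Of the compounds shown here, three have been tested in a functional assay on MDA-MB-231 cells (Homo sapiens) for cytotoxicity, read by MTT assay; on this read-out lower numbers stand for stronger inhibition and higher numbers for weaker inhibition. Compound 1 `COc1ccc(/C=C2\CCC/C(=C\c3ccccc3[N+](=O)[O-])C2=O)cc1` gives 45.1 ug/mL in this assay. Compound 2 `COc1cccc(/C=C2\CCC/C(=C\c3ccccc3[N+](=O)[O-])C2=O)c1` differs from compound 1 by 3-methoxyphenyl in place of 4-methoxyphenyl on a double-bonded chain carbon bound to a double-bonded ring carbon and in this assay compound 2 gives 14.3 ug/mL. That change made a 3.2-fold lower number from compound 1 to compound 2 (0.50 log units; beyond the scatter). Compound 3 `COc1ccc(/C=C2\CCC/C(=C\c3cccc([N+](=O)[O-])c3)C2=O)cc1` carries a different core; the difference between the core of compound 3 and the core of compound 1 is not broken down here. In this assay compound 3 gives 44.7 ug/mL, a number that sits within the scatter of the number for compound 1. Compound 4 `COc1cccc(/C=C2\CCC/C(=C\c3cccc([N+](=O)[O-])c3)C2=O)c1` has not yet been measured; it differs from compound 3 by 3-methoxyphenyl in place of 4-methoxyphenyl on a double-bonded chain carbon bound to a double-bonded ring carbon, the same change that separates compound 2 from compound 1. A step of similar size is expected, a 3.0-fold lower number from compound 3 to compound 4 (0.47 log units; beyond the scatter), set beside the earlier 3.2-fold lower number from compound 1 to compound 2 (0.50 log units; beyond the scatter). That expectation rests on a single measured pair, compound 1 and compound 2, and so carries real uncertainty. Compound 4 is estimated at 15 ug/mL in this assay, with a range from 7 ug/mL to 35 ug/mL.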

Compound 4, half-maximal inhibitory concentration: 13.2 ug/mL
For compound 4 the middle estimate is 1.1-fold (0.06 log units) above the measured one; the range from low to high includes it.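

In this assay, 3-methoxyphenyl in place of 4-methoxyphenyl on a double-bonded chain carbon bound to a double-bonded ring carbon gives a 3.4-fold lower number from compound 3 to compound 4 (0.53 log units; beyond the scatter), and this step matches the earlier one: the same change on two cores in this assay, a 3.2-fold lower number (0.50 log units; beyond the scatter) from compound 1 to compound 2 and a 3.4-fold lower number (0.53 log units; beyond the scatter) from compound 3 to compound 4, 1.1-fold (0.03 log units) apart, within the scatter of two such steps

Within these four compounds, then, the change carries from the core of compound 1 to the core of compound 3 with no difference in size that can be told apart, and none of the four goes against this. Within the data shown here, it does not show that the change would carry to any further core, since only two cores are compared, and it does not explain why the change lowers the number.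

The compounds shown leave open how a hydroxyl group, an amine or a chlorine atom in place of the methoxy group would read in this assay. They also leave open whether the same step would hold on a core that has a nitrile or a carboxylic acid in place of the nitro group.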